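The source may report more compounds than this note shows. Statements on the series, on what has been measured and on what is new or still open speak of the compounds shown alone.

Measured compounds:
compound 1 `COc1ccccc1N1CCN(CCCNC(=O)NN(Cc2ccccc2)c2ccc(Cl)cc2)CC1`, 2.9 nM in an assay on CHO cells for displacement of a labelled ligand from D(4) dopamine receptor (Homo sapiens), read by radioligand binding; a lower number here means a stronger inhibitor, a higher number a weaker inhibitor
compound 2 `COc1ccccc1N1CCN(CCCNC(=O)NN(Cc2ccccc2)c2ccc(Cl)cc2Cl)CC1`, 15 nM in this assay

Compound 2 holds the highest of the two numbers shown in this assay; its nearest neighbour is compound 1, and the step of a 5.2-fold higher number from compound 1 to compound 2 (0.71 log units; beyond the scatter) lies beyond the scatter. Compound 3 `COc1ccccc1N1CCN(CCCNC(=O)NN(Cc2ccccc2)c2ccc(Br)cc2)CC1` has not yet been measured. It differs from compound 2 by 4-bromophenyl in place of 2,4-dichlorophenyl on an amine nitrogen. Going by the values given here, one measured step bears on this: the step of a 5.2-fold higher number from compound 1 to compound 2 (0.71 log units; beyond the scatter) shows that a chloro on the aromatic ring in place of hydrogen raised the number modestly. Among the compounds with values here, compound 3 gives that position back its hydrogen and carries a bromo where compound 1 carries a chloro, a swap for which no measured step exists here. The expected step of a 4.3-fold lower number from compound 2 to compound 3 (0.63 log units; beyond the scatter) is therefore downward, roughly undoing the step from compound 1 to compound 2. Compound 3 is estimated at 3.5 nM in this assay, within 1.2 nM to 10 nM.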

Compound 3, inhibition constant: 3.4 nM
Estimate against measurement, compound 3: 1.0-fold (0.01 log units) above, and the stated range covers the measured number.
By their numbers in this assay, from the lowest: compounds 1 and 3 (each within the scatter of the next); then compound 2.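

In this assay, exchanging one halogen for the other on the aromatic carbon gives a 1.2-fold higher number from compound 1 to compound 3 (0.07 log units; within the scatter) and so leaves the number within the scatter; among these two compounds, chloro and bromo on the ring cannot be told apart. Going by these compounds alone, the wider change, 4-bromophenyl in place of 2,4-dichlorophenyl on the amine nitrogen, gives a 4.4-fold lower number from compound 2 to compound 3 (0.64 log units; beyond the scatter) and shows that the higher number of compound 2 is not shared by either ring with a single halogen, so of these three compounds only the one with the second chloro stands apart. No evidence in hand accounts for these numbers.

The compounds shown leave open whether a 4-fluorophenyl or a 4-methoxyphenyl group on that amine nitrogen would stay level with compound 1 and compound 3. They also leave open whether a 2,4-dibromophenyl group would raise the number as 2,4-dichlorophenyl does.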